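The compounds below may be only part of what the source reports. "The series", "measured", "known", "first", "only" and "open" are said of these compounds alone.

Compound 1 `CCOC(=O)CCC(=O)N1CCN(CCCOc2cc3c(Nc4ccc(F)c(Cl)c4)ncnc3cc2OC)CC1` in a functional assay on A549 cells (Homo sapiens) for cytotoxicity, read by MTT assay, with a stated time of 24 h, tested at 10 uM; on this read-out lower numbers stand for a stronger effect and higher numbers for a weaker effect at the one concentration tested: 77.6%
Compound 2 `CCCCCCCOC(=O)CCC(=O)N1CCN(CCCOc2cc3c(Nc4ccc(F)c(Cl)c4)ncnc3cc2OC)CC1` in this assay: 89.1%

Among the two measured compounds, compound 2 stands highest in this assay, with compound 1 nearest to it at a lower number; the step between them is a number 11.5 percentage points higher from compound 1 to compound 2 (beyond the scatter). Compound 3 `CCCCCCCCCCCCOC(=O)CCC(=O)N1CCN(CCCOc2cc3c(Nc4ccc(F)c(Cl)c4)ncnc3cc2OC)CC1` has not yet been measured in this assay. It differs from compound 2 by pentyl in place of hydrogen on a saturated chain carbon, seven bonds along the chain from an oxygen next to a carbonyl group. For the measured compounds named here, the only measured step that bears on this change is the one that also puts a pentyl in place of a hydrogen on the same chain, a number 11.5 percentage points higher from compound 1 to compound 2 (beyond the scatter), a modest rise that lies beyond the scatter. On the strength of that single step, a further lengthening of the chain in compound 3 is expected to move the number in the same direction, higher, by a modest step, although the read-out cannot climb much further before it reaches its ceiling. For compound 3 the expected step is therefore a number 4.9 percentage points higher from compound 2 to compound 3 (within the scatter). Compound 3 is estimated at 94%, in a range from 82% to 105%.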

Compound 3, a percentage reported as activity, at one concentration (the size of the read-out at that concentration, not a potency): 95.5%
For compound 3 the middle estimate is 1.5 percentage points below the measured one, within the range that was stated.
By their numbers in this assay, from the lowest: compound 1; then compounds 2 and 3 (each within the scatter of the next).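

In this assay, pentyl in place of hydrogen on a saturated chain carbon, seven bonds along the chain from an oxygen next to a carbonyl group, gives a number 6.4 percentage points higher from compound 2 to compound 3 (within the scatter), so at this position the added carbons cannot be told from no change, whereas the earlier step, a number 11.5 percentage points higher from compound 1 to compound 2 (beyond the scatter), lay beyond the scatter. Taken as one change, the whole lengthening of the chain gives a number 17.9 percentage points higher from compound 1 to compound 3 (beyond the scatter), which on this read-out means a weaker effect at the one concentration tested. No measurement shown here accounts for either step.

The compounds shown leave open whether a carboxylic acid or an amine at the far end of the chain, in place of its last carbon, would bring the number in this assay down again. They also leave open how a methyl ester, or a chain bearing a phenyl ring, would read, since all three compounds carry unbranched saturated chains on the same core.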